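The compounds below may be only part of what the source reports. "The series", "measured", "known", "first", "only" and "open" are said of these compounds alone.

Two compounds have been measured in an assay on isolated protein for inhibition of Fatty-acid amide hydrolase 1 (Homo sapiens), read by fluorescence; a higher number here means a weaker inhibitor, a lower number a stronger inhibitor:
compound 1, `O=C(Oc1ccc([N+](=O)[O-])cc1)N1CCN(S(=O)(=O)c2ccc(Oc3ccccc3)cc2)CC1`, which gives 322 nM;
compound 2, `O=C(Oc1ccc([N+](=O)[O-])cc1)N1CCN(S(=O)(=O)c2ccc(Oc3ccc(Cl)c(Cl)c3)cc2)CC1`, which gives 317 nM.

Compound 2 is the starting point for the next step, and on the two numbers shown it stands within the scatter of compound 1: the step of a 1.0-fold lower number from compound 1 to compound 2 (0.01 log units; within the scatter) put 3,4-dichlorophenyl in place of phenyl on an oxygen on an aromatic ring without moving the number beyond what repeated measurements would show. Compound 3, `O=C(Oc1ccc([N+](=O)[O-])cc1)N1CCN(S(=O)(=O)c2ccc(Oc3ccccc3Cl)cc2)CC1`, has not yet been measured. It differs from compound 2 in one place: 2-chlorophenyl in place of 3,4-dichlorophenyl on an oxygen on an aromatic ring. Within the data shown here, the only measured step that touches this part of the molecule is a 1.0-fold lower number from compound 1 to compound 2 (0.01 log units; within the scatter), and it shows that changing the substitution of that ring left the number essentially where it was. Going from 3,4-dichlorophenyl to 2-chlorophenyl is a change of the same kind, so the step of a 1.0-fold higher number from compound 2 to compound 3 (0.00 log units; within the scatter) is expected to be small, with no direction beyond the scatter. Compound 3 is therefore estimated at 320 nM, most likely between 150 nM and 700 nM.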

Compound 3, half-maximal inhibitory concentration: 1150 nM
Estimate against measurement, compound 3: 3.6-fold (0.56 log units) below; measured number outside the range, above it.
By their numbers in this assay, from the lowest: compounds 2 and 1 (each within the scatter of the next); then compound 3.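

In this assay the ring on the oxygen proves sensitive to change after all: the step of a 3.6-fold higher number from compound 1 to compound 3 (0.55 log units; beyond the scatter) comes from chloro in place of hydrogen on an aromatic carbon, so one added chlorine is enough to move the number beyond the scatter. Chlorine alone does not account for the shift, since the step of a 1.0-fold lower number from compound 1 to compound 2 (0.01 log units; within the scatter) adds two chlorines and leaves the number within the scatter, while the step of a 3.6-fold higher number from compound 2 to compound 3 (0.56 log units; beyond the scatter) makes compound 3 the weakest inhibitor of the three, so the pattern of substitution on this ring matters and not simply whether chlorine is present. No measurement shown here explains why the 2-chlorophenyl group and the 3,4-dichlorophenyl group part ways.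

From the compounds shown here alone, with only these three compounds, it remains open whether the rise belongs to chlorine itself or would also appear with a fluoro or methyl group in its place on the same ring. Going by these compounds, it is also open whether a methoxy group or a larger ring on the oxygen would leave the number where compound 1 and compound 2 stand or push it further up.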